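Heptyl to ethyl ester in the sulfated bicyclic series

This account rests on a few compounds, and the source may have more. Where it says the series, first, only, none or still open, it means among the compounds named here.

Two esters of the shared core have been read in an ADME assay on the whole organism for pharmacokinetics, with Cynomolgus monkey (Macaca fascicularis) as the target, read by LC-MS, with a stated time of 24 h, at a dose of 20 mg/kg by the oral route; on this read-out lower numbers stand for lower oral bioavailability and higher numbers for higher oral bioavailability. Compound 1 `CCCCCCCOC(=O)C(C)(C)COS(=O)(=O)ON1C(=O)N2C[C@H]1CC[C@H]2C(N)=O` gives 60%, the highest of the two numbers. For the measured compounds named here, compound 2 `CCCCCCOC(=O)CCC(C)(C)COS(=O)(=O)ON1C(=O)N2C[C@H]1CC[C@H]2C(N)=O` gives 33% in this assay, a number beyond the scatter below that of compound 1; the two differ in more than one place, so no single step is drawn between them. The unmeasured compound 3 `CCOC(=O)C(C)(C)COS(=O)(=O)ON1C(=O)N2C[C@H]1CC[C@H]2C(N)=O` differs from compound 1 in one place: hydrogen in place of pentyl on a saturated chain carbon, two bonds along the chain from an oxygen next to a carbonyl group. Going by the values given here, no measured pair shows this change alone, so the expectation rests on compound 1 only. A modest downward step from compound 1 is expected, a number 15 percentage points lower from compound 1 to compound 3 (beyond the scatter), though the range drawn around it includes no change beyond the scatter. Compound 3 is therefore estimated at 45% in this assay, within 20% to 75%.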

Compound 3, oral bioavailability: 80%
Compound 3: the middle estimate sits 35 percentage points below what was measured; measured number above the stated range.
By their numbers in this assay, from the lowest: compound 2; then compound 1; then compound 3.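

In this assay, cutting the ester chain from heptyl to ethyl, hydrogen in place of pentyl on a saturated chain carbon, gives a number 20 percentage points higher from compound 1 to compound 3 (beyond the scatter). As the only single-place step shown in the series, it indicates that the pentyl portion is not required for the oral bioavailability seen with compound 1, since the shorter ester stands higher on this read-out. No measurement shown bears on why the number rises.

Going by these compounds, a single step at this position gives no trend with chain length, so it remains open whether intermediate chains such as butyl would fall on a steady rise or a peak. Also open, on these data alone, is how a methyl ester, or a chain ending in a carboxylic acid or an amine, would read on the shared core.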